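The source may report more compounds than this note shows. Statements on the series, on what has been measured and on what is new or still open speak of the compounds shown alone.

Measured compounds: compound 1 `COc1ccc(Cn2c(=O)nc(NCCNC(=N)N)n(Cc3ccc(I)cc3)c2=O)cc1` gives 0.039 nM; compound 2 `COc1ccc(Cn2c(NCCNC(=N)N)nc(=O)n(Cc3ccc(Br)cc3)c2=O)cc1` gives 0.00036 nM; compound 3 `COc1ccc(Cn2c(NCCNC(=N)N)nc(=O)n(Cc3ccc(Cl)cc3)c2=O)cc1` gives 0.004 nM.

In a functional assay on the whole organism (strain C57Bl/6) for inhibition, with Mus musculus as the target, with a stated time of 180 min, at 48 degrees C (on this read-out lower numbers stand for an effect already at smaller amounts and higher numbers for an effect only at larger amounts of compound), compound 1 stands highest of the three numbers. Compound 3 is nearest, with a number that the two values show to be lower, and compound 2 is furthest, with a number lower still; both gaps lie beyond the scatter. Going by the values given here, compound 1 differs from compounds 2 and 3 in more than one place, so no single step joins it to them.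

Compound 4 `COc1ccc(Cn2c(=O)nc(NCCNC(=N)N)n(Cc3ccccc3)c2=O)cc1` differs from compound 1 by hydrogen in place of iodo on an aromatic carbon. The only measured step among these compounds is an 11-fold higher number from compound 2 to compound 3 (1.05 log units; beyond the scatter), a large rise on exchanging one halogen for a smaller one. Among the compounds with values here, removing the halogen altogether is a further step of the same kind, so a higher number is expected for compound 4, though the step from bromo to chloro is the only guide and the arrangement in compound 1 is not that of compounds 2 and 3. The estimate for compound 4 is 0.2 nM (range 0.04 nM to 1.5 nM), meaning an expected step of a 5.1-fold higher number from compound 1 to compound 4 (0.71 log units; beyond the scatter).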

Compound 4, half-maximal effective concentration: 0.063 nM
The estimate for compound 4 lay 3.2-fold (0.50 log units) above the measured number; the measured number falls inside the stated range.
By their numbers in this assay, from the lowest: compound 2; then compound 3; then compounds 1 and 4 (each within the scatter of the next).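

In this assay, hydrogen in place of iodo gives a 1.6-fold higher number from compound 1 to compound 4 (0.21 log units; within the scatter), so 4-iodobenzyl and benzyl cannot be told apart on the core of compound 1. Going by these compounds alone, the earlier compounds showed only that this ring's substituent can matter, with an 11-fold higher number from compound 2 to compound 3 (1.05 log units; beyond the scatter) for chloro in place of bromo on a different arrangement of the same groups. The new step shows that exchange at this place need not produce a large step, and that the size seen with bromo and chloro does not carry over to the loss of iodo on the core of compound 1.

The compounds shown leave open whether an amine or a carboxylic acid at this place would also stay within the scatter on the core of compound 1. They also leave open what hydrogen in place of bromo or chloro would give on the arrangement of compound 2 and compound 3. Nothing at hand explains why these two steps differ in size.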